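Replacing methylcarbamoyl with hydroxymethyl on a saturated ring carbon

A few compounds are considered here, and "the series" means these few. Any claim that something is new, unique, unknown or untested is made for them only; others in the source may bear on it.

Measured so far in an ADME assay on microsomes (Mus musculus) for metabolic stability; a lower number here means slower removal, a higher number faster removal of the compound:
Compound 1 `CNC(=O)[C@@H]1CCCN1S(=O)(=O)c1ccc(Cl)c(COc2cccc3c(-n4ccnc4)cc(C)nc23)c1Cl` gives 267 mL/min/kg
Compound 2 `CNC(=O)[C@@H]1CCCN1S(=O)(=O)c1ccc(Cl)c(COc2cccc3c(C(F)(F)F)cc(C)nc23)c1Cl` gives 1380 mL/min/kg
Compound 3 `CCc1cc(C(F)(F)F)c2cccc(OCc3c(Cl)ccc(S(=O)(=O)N4CCC[C@H]4C(=O)NC)c3Cl)c2n1` gives 1280 mL/min/kg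

Compound 2 stands at the top end of these numbers, where removal is fastest. Going by the values given here, two measured steps touch it: a 5.2-fold higher number from compound 1 to compound 2 (0.71 log units; beyond the scatter) with trifluoromethyl in place of 1H-imidazol-1-yl on an aromatic carbon, and a 1.1-fold lower number from compound 2 to compound 3 (0.03 log units; within the scatter) with methyl in place of hydrogen on a saturated chain carbon.

Compound 4 `Cc1cc(C(F)(F)F)c2cccc(OCc3c(Cl)ccc(S(=O)(=O)N4CCC[C@H]4CO)c3Cl)c2n1` keeps the rest of compound 2 but carries hydroxymethyl in place of methylcarbamoyl on a saturated ring carbon, next to the ring nitrogen (hydroxymethyl in place of methylcarbamoyl on a saturated ring carbon). Neither measured step changes that place, so they bear on it only loosely, and the data hold no direct guide. With no evidence for a large shift, the expected result is a 1.3-fold lower number from compound 2 to compound 4 (0.10 log units; within the scatter) and no step beyond the scatter is expected. For compound 4 the estimated value is 1100 mL/min/kg (expected range 500 mL/min/kg to 2200 mL/min/kg).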

Compound 4, clearance: 1630 mL/min/kg
Beside the measured number, compound 4's estimate is 1.5-fold (0.17 log units) below it, within the range that was stated.
By their numbers in this assay, from the lowest: compound 1; then compounds 3, 2 and 4 (each within the scatter of the next).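

In this assay, going by these compounds alone, putting hydroxymethyl in place of methylcarbamoyl on this saturated ring carbon gives a 1.2-fold higher number from compound 2 to compound 4 (0.07 log units; within the scatter) and so gives the first reading at this place. The entering group has 2 heavy atoms against 4 in the group that leaves, yet the two compounds cannot be told apart here, and removal stays as fast as in compound 2. No measurement at hand explains this result.

As far as these compounds go, whether a carboxylic acid, an amine or a longer chain at this ring carbon would shift the number stays open. Also open, from the compounds shown here alone, is whether the same swap would leave the number unmoved on a compound with 1H-imidazol-1-yl in place of trifluoromethyl, such as compound 1 at 267 mL/min/kg in this assay.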